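Chloro to amino on the shared core: compound 4

The source may report more compounds than this note shows. Statements on the series, on what has been measured and on what is new or still open speak of the compounds shown alone.

Compound 1 `ClCc1ccccc1Cn1cnc2c(Cl)nc(Cl)nc21` gives in a functional assay on HT-29 cells (Homo sapiens) for cytotoxicity, read by sulforhodamine B assay, with a stated time of 48 h (on this read-out higher numbers stand for weaker inhibition of growth and lower numbers for stronger inhibition of growth), only a limit, > 100000 nM, not a number. Compound 2 `ClCc1ccc(Cn2cnc3nc(Cl)nc(Cl)c32)cc1` likewise reports a limit in this assay, > 100000 nM. For compound 3 `ClCc1cccc(Cn2cnc3nc(Cl)nc(Cl)c32)c1` this assay gives "not determined" (no result reported). Among the measured compounds shown here, no step between two compounds differing in one place is measured; the only evidence on the values is the limit of > 100000 nM in this assay, at which 2 of the 3 values shown sit. Compound 1 thus stands at the limit of this assay, alongside compound 2, and the numbers shown give no ranking of the two.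

Compound 4 `Nc1nc(Cl)c2ncn(Cc3ccccc3CCl)c2n1` differs from compound 1 by amino in place of chloro on an aromatic carbon. For the measured compounds named here, with no measured step to lean on, and with compound 1 itself at the limit, the expected step is a number no higher from compound 1 to compound 4 (the limit leaves the size open), none beyond the scatter. For compound 4 the estimate in this assay is 100000 nM, within 20000 nM to 300000 nM, and a further limit rather than a number is expected as the likelier outcome.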

Compound 4, concentration for total growth inhibition: 19100 nM
For compound 4 the middle estimate is 5.2-fold (0.72 log units) above the measured one; the measured number lies below the stated range.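

In this assay, amino in place of chloro at the carbon between two ring nitrogen atoms gives an at least 5.2-fold lower number from compound 1 to compound 4 (0.71 log units; beyond the scatter), so this position responds to the change. Compound 4, at 19100 nM, is the only compound shown with a number rather than a limit, which means the shared core can give a readable value on this read-out once this chloro group gives way to amino. The step remains a bound and not a size: the limit of > 100000 nM in this assay, at which 2 of the 4 values shown sit.

From the compounds shown here alone, whether the result is specific to amino or would extend to a methylamino or a hydroxyl group at this position remains open. Also open, going by these compounds, are whether the same change would act alike on compound 2 and what replacing the remaining chloro group would do.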